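This account rests on a few compounds, and the source may have more. Where it says the series, first, only, none or still open, it means among the compounds named here.

Measured in a functional assay on HT-29 cells (Homo sapiens) for antiproliferative activity, read by MTT assay, with a stated time of 72 h; a higher number here means a weaker inhibitor, a lower number a stronger inhibitor:
- Compound 1 `O=C1C=C(N2CCN(c3ccccc3Cl)CC2)C(=O)c2ccccc21`: 18900 nM
- Compound 2 `O=C1C=C(N2CCC(c3ccccc3)CC2)C(=O)c2c(O)cccc21`: 5400 nM
- Compound 3 `O=C1C=C(N2CCC(c3ccc(Cl)cc3)CC2)C(=O)c2c(O)cccc21`: 6900 nM

Compound 3, at 6900 nM, stands within the scatter of compound 2 and well below compound 1, at 18900 nM. Compound 4 `Cc1ccccc1C1CCN(C2=CC(=O)c3cccc(O)c3C2=O)CC1` differs from compound 3 as follows: 2-methylphenyl in place of 4-chlorophenyl on a saturated ring carbon. In words, this is 2-methylphenyl in place of 4-chlorophenyl on a saturated ring carbon. Among the compounds with values here, the only measured step that bears on this change is a 1.3-fold higher number from compound 2 to compound 3 (0.11 log units; within the scatter), with chloro in place of hydrogen on an aromatic carbon. Within the data shown here, no measured compound carries 2-methylphenyl, so that step is only a partial guide. No step beyond the scatter is therefore expected in this assay. The estimated change is a 1.2-fold lower number from compound 3 to compound 4 (0.06 log units; within the scatter). Compound 4 is estimated at 6000 nM, with an expected range from 2800 nM to 13000 nM.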

Compound 4, half-maximal inhibitory concentration: 6700 nM
The estimate for compound 4 lay 1.1-fold (0.05 log units) below the measured number; low and high end bracket the measured number.
By their numbers in this assay, from the lowest: compounds 2, 4 and 3 (each within the scatter of the next); then compound 1.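

In this assay the exchange of 4-chlorophenyl for 2-methylphenyl on a saturated ring carbon gives a 1.0-fold lower number from compound 3 to compound 4 (0.01 log units; within the scatter) and the addition of a methyl alone gives a 1.2-fold higher number from compound 2 to compound 4 (0.09 log units; within the scatter). The aromatic ring at this position thus carries a methyl as well as a chloro without any step beyond the scatter among compound 2, compound 3 and compound 4. No evidence bearing on this result is available. On these data alone, whether an amine or a carboxylic acid on that ring would give a step beyond the scatter remains open.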